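A few compounds are considered here, and "the series" means these few. Any claim that something is new, unique, unknown or untested is made for them only; others in the source may bear on it.

Compound 1 `Cc1ccccc1NC(=O)Nc1cc(C(C)(C)C)nn1-c1ccccc1`: 1.2 degrees C
Compound 2 `CC(C)(C)c1cc(NC(=O)Nc2cc(C(F)(F)F)cc(C(F)(F)F)c2)n(-c2ccccc2)n1`: 0.8 degrees C
Compound 3 `CC(C)(C)c1cc(NC(=O)Nc2ccccc2)n(-c2ccccc2)n1`: 1.6 degrees C

These three values come from an assay on isolated protein for inhibition of Ephrin type-A receptor 2 (Homo sapiens), read by thermal shift assay, tested at 10 uM; a higher number here means that the compound stabilises the target more against heat, a lower number that the compound stabilises the target less. Compound 3 and compound 1 differ in one place: methyl in place of hydrogen on an aromatic carbon. Within the data shown here, that change gave a number 0.40 degrees C lower from compound 3 to compound 1 (within the scatter), so the methyl made no step that can be told apart from noise. Compound 2 and compound 3 share the urea but differ in more than one place; the difference between the two cores is not broken down here. Compound 4 `Cc1ccc(-n2nc(C(C)(C)C)cc2NC(=O)Nc2cc(C(F)(F)F)cc(C(F)(F)F)c2)cc1` is built from compound 2 by methyl in place of hydrogen on an aromatic carbon. This is the same kind of change as from compound 3 to compound 1, not the same: there the methyl sits ortho to a large group, here it sits para to a large group, and it is made on a different core.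

Because the step of a number 0.40 degrees C lower from compound 3 to compound 1 (within the scatter) lies within the scatter, the expected step from compound 2 to compound 4 in this assay is also small, a number 0.20 degrees C lower from compound 2 to compound 4 (within the scatter). Compound 4 is therefore estimated at 0.6 degrees C, with a likely range from -0.6 degrees C to 1.8 degrees C.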

Compound 4, shift of the target's melting temperature: 0.8 degrees C
Compound 4: the middle estimate sits 0.20 degrees C below what was measured; low and high end bracket the measured number.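

In this assay, the change from phenyl to 4-methylphenyl gave no change at the digits printed from compound 2 to compound 4 (within the scatter), so this methyl leaves no mark that can be told apart from noise. Set beside the earlier methyl step, the result gives no sign that the core alters what this change does, as far as this read-out can tell: the same change on two cores in this assay, a number 0.40 degrees C lower (within the scatter) from compound 3 to compound 1 and no change at the digits printed (within the scatter) from compound 2 to compound 4, 0.40 degrees C apart, within the scatter of two such steps This does not show that the change carries over reliably from core to core, since it rests on only two pairs of compounds, the methyl does not sit at the same place in both pairs, and neither step stands clear of the scatter.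

The compounds shown leave open what a group other than methyl, such as a chlorine atom, a methoxy group, an amine or a carboxylic acid, would do on the same ring. They also leave open whether any such group would give a step large enough to compare properly between the two cores.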